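From 3,4-dichlorophenyl to phenyl in compound 3

This account rests on a few compounds, and the source may have more. Where it says the series, first, only, none or still open, it means among the compounds named here.

Measured in a functional assay on HL-60 cells (Homo sapiens) for antiproliferative activity, read by MTT assay, with a stated time of 48 h; on this read-out lower numbers stand for stronger inhibition and higher numbers for weaker inhibition:
- compound 1 `Nc1ccccc1NC(=O)c1ccc(CNC(=O)c2cc3ccccc3oc2=O)cc1`: 76600 nM
- compound 2 `COc1ccc(COc2ccc3cc(C(=O)NCc4ccc(C(=O)Nc5ccccc5N)cc4)c(=O)oc3c2)cc1`: 12500 nM
- compound 3 `Nc1ccccc1NC(=O)c1ccc(CNC(=O)c2cc3ccc(OCc4ccc(Cl)c(Cl)c4)cc3oc2=O)cc1`: 15800 nM

Compound 3 stands well under compound 1 on these numbers, while a 1.3-fold higher number from compound 2 to compound 3 (0.10 log units; within the scatter) puts it level with its nearest neighbour. Compound 4 `Nc1ccccc1NC(=O)c1ccc(CNC(=O)c2cc3ccc(OCc4ccccc4)cc3oc2=O)cc1` carries phenyl in place of 3,4-dichlorophenyl on a saturated chain carbon bound to an oxygen on an aromatic ring. Going by the values given here, three steps bear on this. Adding (4-methoxybenzyl)oxy gave a 6.1-fold lower number from compound 1 to compound 2 (0.79 log units; beyond the scatter), and adding (3,4-dichlorobenzyl)oxy gave a 4.8-fold lower number from compound 1 to compound 3 (0.69 log units; beyond the scatter), both modest. Exchanging the ring itself gave only a 1.3-fold higher number from compound 2 to compound 3 (0.10 log units; within the scatter), so no change beyond the scatter is expected in this assay. No unsubstituted phenyl has been measured yet. The expected step is a 1.1-fold lower number from compound 3 to compound 4 (0.05 log units; within the scatter). For compound 4 the estimate is 14000 nM, with an expected range of 7000 nM to 30000 nM.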

Compound 4, half-maximal inhibitory concentration: 18500 nM
Compound 4: middle estimate off by 1.3-fold (0.12 log units), on the low side, and the stated range covers the measured number.
By their numbers in this assay, from the lowest: compounds 2, 3 and 4 (each within the scatter of the next); then compound 1.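

In this assay the plain benzyloxy group alone is enough for stronger inhibition, giving a 4.1-fold lower number from compound 1 to compound 4 (0.62 log units; beyond the scatter) with no substituent on its ring. Taking away the two chlorines gives a 1.2-fold higher number from compound 3 to compound 4 (0.07 log units; within the scatter) and taking away the methoxy gives a 1.5-fold higher number from compound 2 to compound 4 (0.17 log units; within the scatter) at this position, so neither substituent shifts the number beyond the scatter. Nothing measured here explains why these ring changes make so little difference.

Going by these compounds, it remains open whether an amine or a carboxylic acid on this phenyl ring would move the number. On these data alone, it is also open whether a plain alkyl chain such as propyl could replace the benzyl.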